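The compounds below may be only part of what the source reports. "The series", "measured", "known", "first", "only" and "open" are said of these compounds alone.

Measured in a functional assay on DU-145 cells (Homo sapiens) for inhibition, read by trypan blue exclusion, with a stated time of 96 h; on this read-out higher numbers stand for weaker inhibition of growth and lower numbers for stronger inhibition of growth:
- compound 1 `O=C(/C(=C\c1ccc(O)cc1)SCc1ccc(Cl)cc1)c1ccc(Cl)cc1`: 10000 nM
- compound 2 `O=C(/C(=C\c1cccc(Cl)c1Cl)SCc1ccc(Cl)cc1)c1ccc(Cl)cc1`: 10000 nM

Level with compound 1, compound 2 stands at 10000 nM. Compound 3 `CSc1ccc(/C=C(/SCc2ccc(Cl)cc2)C(=O)c2ccc(Cl)cc2)cc1`, not yet measured, differs from it by 4-(methylsulfanyl)phenyl in place of 2,3-dichlorophenyl on a double-bonded chain carbon bound to a double-bonded chain carbon. Within the data shown here, only one measured step bears on this place, no change at the digits printed from compound 1 to compound 2 (within the scatter), so the evidence is thin. On that step, no change beyond the scatter is expected in this assay. The expected step is a 1.3-fold lower number from compound 2 to compound 3 (0.10 log units; within the scatter). For compound 3 the estimated value is 8000 nM, with an expected range of 2500 nM to 20000 nM.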

Compound 3, concentration for 50% growth inhibition: 25000 nM
Estimate against measurement, compound 3: 3.1-fold (0.49 log units) below, outside the stated range (above it).
By their numbers in this assay, from the lowest: compounds 1 and 2 (each within the scatter of the next); then compound 3.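

This position is not indifferent to its substituent in this assay: the number can move beyond the scatter, with 4-(methylsulfanyl)phenyl giving a 2.5-fold higher number from compound 2 to compound 3 (0.40 log units; beyond the scatter) and weaker inhibition of growth. Methylsulfanyl in place of hydroxy on an aromatic carbon gives a 2.5-fold higher number from compound 1 to compound 3 (0.40 log units; beyond the scatter), so both comparisons point the same way. No measurement at hand accounts for these steps.

On these data alone, it remains open how an amine or a carboxylic acid would behave at this place, and whether a longer chain on the sulfur would move the number further.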